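A few compounds are considered here, and "the series" means these few. Any claim that something is new, unique, unknown or untested is made for them only; others in the source may bear on it.

Compound 1, `COc1ccc(-c2nnc(SCC(=O)c3ccccc3)n2-c2ccccc2)cc1OC`: 59%
Compound 2, `O/N=C(/CSc1nnc(-c2ccccc2)n1-c1ccccc1)c1ccccc1`: 75%

For the measured compounds named here, in a functional assay on the whole organism (strain albino) for inhibition, with Rattus norvegicus as the target, read by paw edema, with a stated time of 5 h, at a dose of 0.28 mmol/kg by the oral route (on this read-out higher numbers stand for more inhibition at the one dose given (going by the name of the read-out) and lower numbers for less inhibition), compound 2 gives 75%, the higher of the two numbers measured so far. Its nearest neighbour on this read-out is compound 1, which in this assay gives 59%, a value that lies beyond the usual scatter from that of compound 2. Going by the values given here, the two measured compounds differ from each other in more than one place, so no single step between them can be quoted, and the two values can only be set side by side.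

The next compound, compound 3, `COc1ccc(-c2nnc(SC/C(=N/O)c3ccccc3)n2-c2ccccc2)cc1OC`, is derived from compound 2 by 3,4-dimethoxyphenyl in place of phenyl on an aromatic carbon. Nothing measured isolates the effect of this change on its own. Because compound 2 gives 75% and compound 1, which carries the same 3,4-dimethoxyphenyl group, gives 59%, compound 3 is expected to fall somewhere between them, with a modest downward step from compound 2 that may not exceed the scatter. The expected step is a number 10 percentage points lower from compound 2 to compound 3 (within the scatter). Compound 3 is therefore estimated at 65%, within a range from 50% to 80%.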

Compound 3, a percentage reported as inhibition, in the whole organism at one dose (the size of the read-out at that dose, not a potency): 78%
The estimate for compound 3 lay 13 percentage points below the measured number; the measured number falls inside the stated range.
By their numbers in this assay, from the lowest: compound 1; then compounds 2 and 3 (each within the scatter of the next).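

In this assay, a number 3 percentage points higher from compound 2 to compound 3 (within the scatter) follows from putting 3,4-dimethoxyphenyl in place of phenyl on the aromatic carbon between two ring nitrogen atoms, so this position accepts the larger group, with its two added oxygen atoms, without a difference that can be told from the scatter. The other step gives the first one-place comparison on the chain: with a group of 9 heavy atoms, one of them nitrogen, in place of a group of 8 heavy atoms on the saturated chain carbon bound to a sulfur, this assay shows a number 19 percentage points higher from compound 1 to compound 3 (beyond the scatter), a modest change that does lie beyond the scatter, and so the difference among these compounds goes with the chain and not with the aromatic group. Nothing available gives a measured reason for either step.

From the compounds shown here alone, it remains open whether the aromatic carbon would read the same with a single methoxy group, a chlorine or an amine on the phenyl ring, or whether the chain would hold its reading with a methyl ether on the oxime oxygen or a longer chain before the sulfur. It is also open whether the 3,4-dimethoxyphenyl exchange would read the same on a compound that keeps the carbonyl, and how any of these compounds would compare across a range of doses.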